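The source may hold more compounds than are shown below. What is called first, only, known or untested is meant among the compounds shown, and "the series" means these compounds.

Compound 1 `Cc1ccccc1C(=O)NNC(=O)c1cccc(NS(=O)(=O)c2cnc(O)nc2O)c1`: in a functional assay on A549 cells (Homo sapiens) for antiproliferative activity, read by MTT assay, with a stated time of 24 h (on this read-out lower numbers stand for stronger inhibition and higher numbers for weaker inhibition), compound 1 gives 8010 nM.
Compound 2 `Cc1ccc(C(=O)NNC(=O)c2cccc(NS(=O)(=O)c3cnc(O)nc3O)c2)cc1`: in this assay compound 2 reaches only a limit of the assay, > 20000 nM.
Compound 3 `Cc1ccccc1C(=O)NNC(=O)c1ccccc1NS(=O)(=O)c1cnc(O)nc1O`: in this assay compound 3 gives 5450 nM.

Compound 4 `Cc1ccc(C(=O)NNC(=O)c2ccccc2NS(=O)(=O)c2cnc(O)nc2O)cc1` has not yet been measured. The difference between the core of compound 3 and the core of compound 1 is not broken down here; their two values lie within the scatter of each other. Compound 2 arises from compound 1 by 4-methylphenyl in place of 2-methylphenyl on a carbonyl carbon, and this gave an at least 2.4-fold higher number from compound 1 to compound 2 (0.39 log units; beyond the scatter), with compound 2 sitting at the limit of > 20000 nM in this assay, at which 1 of the 3 values shown sits. Compound 4 arises from compound 3 by the same change, (4-methylphenyl in place of 2-methylphenyl on a carbonyl carbon), at the same kind of place, a carbonyl carbon whose other neighbour is an amide-type nitrogen. Because the earlier step was an at least 2.4-fold higher number from compound 1 to compound 2 (0.39 log units; beyond the scatter), a step of similar size is expected here, a 2.8-fold higher number from compound 3 to compound 4 (0.44 log units; beyond the scatter). Compound 4 is therefore estimated at 15000 nM, plausibly between 7000 nM and 35000 nM, with a real chance that only a limit is reported.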

Compound 4, half-maximal inhibitory concentration: > 20000 nM
Compound 4: no number, only a limit; the forecaster's own chance of this, stated with the estimate: 35%; middle value at least 1.3-fold (0.12 log units) away from the limit.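

Replacing 2-methylphenyl with 4-methylphenyl on the carbonyl carbon gave, in this assay, an at least 3.6-fold higher number from compound 3 to compound 4 (0.56 log units; beyond the scatter), so the change went the same way on both cores: the same change on two cores in this assay, an at least 2.4-fold higher number (0.39 log units; beyond the scatter) from compound 1 to compound 2 and an at least 3.6-fold higher number (0.56 log units; beyond the scatter) from compound 3 to compound 4; the limit leaves it open whether they differ

Compound 4 gives only a limit, > 20000 nM. The true size of each step therefore remains unknown, so the data do not show that the change carries over with the same magnitude: the limit of > 20000 nM in this assay, at which 2 of the 4 values shown sit.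

The compounds shown leave open how activity would respond if an amine or a carboxylic acid took the place of the methyl group. They also leave open whether the same change would go the same way on cores beyond these two.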